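Carboxy in place of 2-hydroxyethyl: a binding estimate

The source may hold more compounds than are shown below. What is called first, only, known or untested is meant among the compounds shown, and "the series" means these compounds.

In an ADME assay on a cell-free system (plasma, Rattus norvegicus) for protein binding, compound 1 (`Cn1cc(C(=O)Nc2ccc(-c3ccccc3)c(C(F)(F)F)c2)c(=O)c2cnccc21`) gives 91.7%, compound 2 (`Cn1cc(C(=O)Nc2ccc(-c3ccccc3)c(C(F)(F)F)c2)c(=O)c2ccc(CO)cc21`) gives 92.4% and compound 3 (`Cn1cc(C(=O)Nc2ccc(-c3ccccc3)c(C(F)(F)F)c2)c(=O)c2ccc(CCO)cc21`) gives 92.7%. These three values lie within the scatter of each other, so compound 3 stands level with the other two. Compound 4 (`Cn1cc(C(=O)Nc2ccc(-c3ccccc3)c(C(F)(F)F)c2)c(=O)c2ccc(C(=O)O)cc21`) carries carboxy in place of 2-hydroxyethyl on an aromatic carbon. Within the data shown here, the one measured step bearing on this is a 1.0-fold lower unbound fraction from compound 2 to compound 3 (0.02 log units; within the scatter). That step involves no carboxy group, so the data give no direct guide to this change. A small move towards more bound compound is expected, possibly none beyond the scatter. The expected step is a 1.5-fold lower unbound fraction from compound 3 to compound 4 (0.16 log units; within the scatter). Compound 4 is estimated at 95%, with an expected range of 90% to 99%.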

Compound 4, plasma protein binding: 98%
Beside the measured number, compound 4's estimate is 2.5-fold (0.40 log units) (unbound fraction) above it, within the range that was stated.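

At this aromatic carbon, hydroxymethyl and 2-hydroxyethyl stood within the scatter of each other, whereas carboxy separates from both in this assay: the change gives a 3.7-fold lower unbound fraction from compound 3 to compound 4 (0.56 log units; beyond the scatter), and the comparison with the shorter chain gives a 3.8-fold lower unbound fraction from compound 2 to compound 4 (0.58 log units; beyond the scatter). The read-out at this position therefore can respond to the group placed there, at least for carboxy. No measurement here accounts for the shift. Open, on these data alone, is whether an amine or a methyl ester at this place would move the read-out likewise, and whether a longer chain ending in a carboxylic acid would keep the shift.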